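Compound 2 to compound 4: methyl in place of hydrogen

This account rests on a few compounds, and the source may have more. Where it says the series, first, only, none or still open, it means among the compounds named here.

Compound 2 `COc1cc2c(/C=C3/C(=O)Nc4ccc(O)cc43)c(Cl)n(Cc3cc(OC)c(OC)c(OC)c3)c2cc1C` gives the lowest number of the three measured in a functional assay on cells (Cancer cell lines, Homo sapiens) for cytotoxicity, with a stated time of 48 h (on this read-out higher numbers stand for weaker inhibition of growth and lower numbers for stronger inhibition of growth), at 2340 nM. Compound 1 `COc1c(/C=C2/C(=O)Nc3ccc(Cl)cc32)c2ccccc2n1-c1ccccc1` comes nearest, at 8510 nM, a gap beyond the scatter, and compound 3 `COc1cc2c(cc1C)NC(=O)/C2=C/c1c(Cl)n(Cc2cc(OC)c(OC)c(OC)c2)c2cc(C)c(OC)cc12` lies furthest, at 30900 nM, also beyond the scatter. Compound 4 `COc1ccc2c(c1)/C(=C\c1c(Cl)n(Cc3cc(OC)c(OC)c(OC)c3)c3cc(C)c(OC)cc13)C(=O)N2` is not yet measured. It differs from compound 2 in one place: methyl in place of hydrogen on an oxygen on an aromatic ring. Going by the values given here, no measured pair in the set carries this same change, so the size of the step rests on expectation alone. A step of moderate size toward weaker inhibition of growth is expected, a 1.9-fold higher number from compound 2 to compound 4 (0.28 log units; within the scatter), at the edge of the scatter or a little beyond it. For compound 4 the value in this assay is estimated at 4500 nM, with a range of 1500 nM to 13000 nM.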

Compound 4, concentration for 50% growth inhibition: 33100 nM
The estimate for compound 4 lay 7.4-fold (0.87 log units) below the measured number; measured number above the stated range.
By their numbers in this assay, from the lowest: compound 2; then compound 1; then compounds 3 and 4 (each within the scatter of the next).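

In this assay, capping the hydroxy on the aromatic ring as methoxy is costly, with a 14-fold higher number from compound 2 to compound 4 (1.15 log units; beyond the scatter) as the step, so this oxygen's free hydrogen counts for far more than the first three compounds could show. Hydrogen in place of methyl on an aromatic carbon leaves the read-out unchanged within the scatter (a 1.1-fold higher number from compound 3 to compound 4 (0.03 log units; within the scatter)), so that site tolerates the change in the methoxy-bearing compounds. Nothing available explains the large step.

Open, from the compounds shown here alone, is whether an amine or a carboxylic acid in place of the hydroxy would hold the level of compound 2. Also open, going by these compounds, is how a longer chain on the oxygen would compare with methoxy.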